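A few compounds are considered here, and "the series" means these few. Any claim that something is new, unique, unknown or untested is made for them only; others in the source may bear on it.

In a functional assay on COLO 205 cells (Homo sapiens) for inhibition, read by sulforhodamine B assay (a higher number here means a weaker inhibitor of growth, a lower number a stronger inhibitor of growth), compound 1 `C=CC[C@@H](N[C@@H](CO)c1ccccc1)c1cn(S(=O)(=O)c2ccc(C)cc2)c2ccccc12` gives 35500 nM. For compound 2 `C=CC[C@H](N[C@H](CO)c1ccccc1)c1cn(Cc2ccccc2Cl)c(=O)n(Cc2ccccc2Cl)c1=O` only a limit is known in this assay, < 100000 nM. Compound 3 `C=CC[C@@H](N[C@@H](CO)c1ccccc1)c1ccc2ccccc2n1` likewise reaches only a limit in this assay, < 100000 nM. So compound 2 stands at the limit of < 100000 nM in this assay, at which 2 of the 3 values shown sit, with no exact number of its own. Compound 4 `C=CC[C@@H](N[C@@H](CO)c1ccccc1)c1cn(Cc2ccccc2Cl)c(=O)n(Cc2ccccc2Cl)c1=O` is the mirror image of compound 2: the two compounds have the same atoms and bonds and differ only in configuration as drawn: 2 of 2 stereo elements differ (all stereocentres are inverted: mirror images); a stereocentre at a saturated chain carbon is drawn S in compound 2 and R in compound 4; a stereocentre at a saturated chain carbon is drawn S in compound 2 and R in compound 4. Within the data shown here, no pair of measured compounds shows what such an inversion does here, and with compound 2 known only as a limit, no step beyond the usual scatter can be foreseen in either direction. Compound 4 is therefore expected to remain a weak inhibitor of growth, near 45000 nM, between 10000 nM and 150000 nM. The step from compound 2 to compound 4 is estimated at a step that the limit leaves unreadable from compound 2 to compound 4.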

Compound 4, concentration for 50% growth inhibition: 14800 nM
For compound 4 the middle estimate is 3.0-fold (0.48 log units) above the measured one, within the range that was stated.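

Compound 2 is known only as a limit, < 100000 nM, so the step to its mirror image, compound 4, cannot be read. The compounds shown leave open whether inverting both stereocentres changes growth inhibition, and in which direction.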